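Two measured diaryl compounds and a dimethylphenyl variant to come

The source may report more compounds than this note shows. Statements on the series, on what has been measured and on what is new or still open speak of the compounds shown alone.

Compound 1 `COCOc1cc(C2=C(c3cc(OC)c(OC)c(OC)c3)C(=O)CC2O[SiH2]C(C)(C)C)ccc1OC`: in an ADME assay on ECV-304 cells (Homo sapiens) for cytotoxicity, read by MTT assay, with a stated time of 72 h (a higher number here means a weaker inhibitor, a lower number a stronger inhibitor), compound 1 gives 40 ug/mL.
Compound 2 `C=CCOc1cc(C2=C(c3cc(OC)c(OC)c(OC)c3)C(=O)C(O)C2)ccc1OC`: in this assay compound 2 gives only a limit, > 100 ug/mL.

Going by the values given here, compound 1 is the one compound here with an actual number in this assay; the other value shown is a limit, (the limit of > 100 ug/mL in this assay, at which 1 of the 2 values shown sits). Compound 3 `COc1cc(C2=C(c3cc(C)c(OC)c(C)c3)C(O[SiH2]C(C)(C)C)CC2=O)cc(OC)c1OC` differs from compound 1 at a single place: 4-methoxy-3,5-dimethylphenyl in place of 4-methoxy-3-(methoxymethoxy)phenyl on a double-bonded ring carbon. Among the compounds with values here, no step between measured compounds is available to gauge such a change, so the size of the move is open. In this assay the expected step is no change at the digits printed from compound 1 to compound 3 (within the scatter), which is no larger than the usual scatter of the assay and in no fixed direction. Compound 3 is accordingly expected to give about 40 ug/mL in this assay, with a range from 15 ug/mL to 100 ug/mL, the upper end reaching the region where the assay may report only a limit.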

Compound 3, half-maximal inhibitory concentration: 15 ug/mL
For compound 3 the middle estimate is 2.7-fold (0.43 log units) above the measured one; measured number inside the range.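

In this assay, placing 4-methoxy-3,5-dimethylphenyl in place of 4-methoxy-3-(methoxymethoxy)phenyl on the double-bonded ring carbon gives a 2.7-fold lower number from compound 1 to compound 3 (0.43 log units; beyond the scatter), the first single change shown to move the read-out beyond the scatter. The entering group has fewer heavy atoms and fewer hydrogen-bond acceptors than the group it replaces, so the methoxymethoxy group is not needed for a measurable number at this position, and here the number moves towards a stronger inhibitor. Nothing measured here gives a cause for this step.

The compounds shown do not separate the loss of the methoxymethoxy group from the gain of the methyl groups, since both belong to the same change. They also leave open how a phenyl group bearing an amine or a carboxylic acid at this position would read in this assay.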